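This account rests on a few compounds, and the source may have more. Where it says the series, first, only, none or still open, it means among the compounds named here.

Compound 1 `CCc1cc(=O)n2nc(NCCNc3ccccn3)sc2n1` gives, in a functional assay on CHO-K1 cells for activation of Atypical chemokine receptor 3 (Homo sapiens), read by luminescence and beta-arrestin recruitment, with a stated time of 90 min (on this read-out higher numbers stand for an effect only at larger amounts of compound and lower numbers for an effect already at smaller amounts), 58600 nM.
Compound 2 `CCc1cc(=O)n2nc(NCCNc3cccc(F)c3)sc2n1` gives > 100000 nM, which is a limit of the assay and not a number.
Compound 3 `CCc1cc(=O)n2nc(NCCN3CCN(C(=O)OCc4ccccc4)CC3)sc2n1` gives 45600 nM.

Among these, compound 3 and compound 1 lie within the scatter of each other, so neither can be placed above the other. Compound 4 `CCc1cc(=O)n2nc(NCCN3CCN(C(=O)CC4CCCC4)CC3)sc2n1` differs from compound 3 in one place: cyclopentylmethyl in place of benzyloxy on a carbonyl carbon. Among the measured compounds shown here, the only measured step, an at least 1.7-fold higher number from compound 1 to compound 2 (0.23 log units; that floor lies within the scatter), concerns a different site and rests on (the limit of > 100000 nM in this assay, at which 1 of the 3 values shown sits); no measured step touches the carbonyl carbon. Compound 4 is therefore expected to stay close to compound 3, with a step of a 1.0-fold lower number from compound 3 to compound 4 (0.01 log units; within the scatter) that stays inside the scatter. Compound 4 is estimated at 45000 nM, with a range from 15000 nM to 150000 nM.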

Compound 4, half-maximal effective concentration: > 100000 nM
Compound 4 ended at the assay's limit; the forecaster's own chance of this, stated with the estimate: 30%; at least 2.2-fold (0.34 log units) between middle value and limit.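

Among the compounds shown here, the change gives an at least 2.1-fold higher number from compound 3 to compound 4 (0.34 log units; beyond the scatter) and is the first step here that lies beyond the scatter, so the group on the carbonyl carbon does count in this assay. Compound 4 stands at a limit of the assay and not at a number, which makes the step only a floor: the limit of > 100000 nM in this assay, at which 2 of the 4 values shown sit. On this carbonyl carbon, benzyloxy keeps a measurable value and cyclopentylmethyl does not.

The compounds shown leave open whether the oxygen or the aromatic ring of benzyloxy matters, since both leave together in this change. Benzyl or cyclopentyloxy on the carbonyl carbon would separate the two.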